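Aryl replacement at the picolinamide end of the series

A few compounds are considered here, and "the series" means these few. Any claim that something is new, unique, unknown or untested is made for them only; others in the source may bear on it.

Measured compounds:
compound 1 `COc1cc2c(Oc3ccc(NC(=O)c4cc(-c5ccccc5)ccn4)cc3F)ccnc2cc1OCCCN1CCN(C)CC1` — 91 nM
compound 2 `COc1cc2c(Oc3ccc(NC(=O)c4cc(-c5ccccc5F)ccn4)cc3F)ccnc2cc1OCCCN1CCCCC1` — 130 nM
compound 3 `COc1cc2c(Oc3ccc(NC(=O)c4cc(-c5ccccc5)ccn4)cc3F)ccnc2cc1OCCCN1CCCC1` — 130 nM

All three numbers come from a functional assay on NCI-H460 cells (Homo sapiens) for cytotoxicity, read by MTT assay, with a stated time of 72 h; on this read-out lower numbers stand for stronger inhibition and higher numbers for weaker inhibition. Compound 3 is level with compound 2 at the digits shown, and together they hold the highest of the three numbers; compound 1 stands nearest, and the step of a 1.4-fold higher number from compound 1 to compound 3 (0.15 log units; within the scatter) lies within the scatter. Compounds 1 and 2 differ in two places, so their values show only that both sit close to compound 3.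

The next compound, compound 4 `COc1ccc(-c2ccnc(C(=O)Nc3ccc(Oc4ccnc5cc(OCCCN6CCCC6)c(OC)cc45)c(F)c3)c2)c(OC)c1`, keeps the whole of compound 3 and changes only the aryl group on the pyridine ring: 2,4-dimethoxyphenyl in place of phenyl on an aromatic carbon.

Within the data shown here, no measured step touches this aryl group. Among the measured compounds shown here, the one step in hand, from compound 1 to compound 3, concerns the amine at the end of the chain and stays within the scatter, so it says nothing about the change from phenyl to 2,4-dimethoxyphenyl. With nothing in the data to point either way, no step beyond the scatter is expected in this assay for compound 4, and the estimate therefore sits on the value of compound 3: a 1.2-fold higher number from compound 3 to compound 4 (0.06 log units; within the scatter).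

Compound 4 is estimated at 150 nM, with a range from 50 nM to 450 nM.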

Compound 4, half-maximal inhibitory concentration: 520 nM
Compound 4: the middle estimate sits 3.5-fold (0.54 log units) below what was measured; the measured number lies above the stated range.
By their numbers in this assay, from the lowest: compounds 1, 2 and 3 (each within the scatter of the next); then compound 4.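

Among these compounds, the aryl group on the pyridine ring, opposite the ring nitrogen, is the first place where a single change goes beyond the scatter in this assay: 2,4-dimethoxyphenyl in place of phenyl gives weaker inhibition (a 4.0-fold higher number from compound 3 to compound 4 (0.60 log units; beyond the scatter)). Among the compounds shown here, the one earlier step, at the amine on the end of the chain, stayed within the scatter, so this position is not neutral in the way that amine change was, and a phenyl carrying these two methoxy groups is not tolerated as well as plain phenyl. For the compounds shown here, nothing measured so far accounts for this loss.

The compounds shown leave open whether one methoxy group alone would carry the same step or whether both are needed, and whether a smaller substituent such as a hydroxyl or a chlorine on the phenyl ring would behave the same way. On these data alone, it also remains open whether the step holds with 4-methylpiperazin-1-yl at the end of the chain, and the 2-fluorophenyl of compound 2 cannot be read against phenyl, since that pair differs in two places.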